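The compounds below may be only part of what the source reports. "The series", "measured", "known", "first", "only" and "open" are said of these compounds alone.

- compound 1 `CCCCC(=O)N(Cc1ccc(OC)c(O)c1)c1cc(OC)c(OC)c(OC)c1` gives 66 nM
- compound 2 `COc1ccc(CN(C(=O)C(C)Br)c2cc(OC)c(OC)c(OC)c2)cc1O` gives 120 nM
- compound 3 `C/C=C/C=C/C(=O)N(Cc1ccc(OC)c(O)c1)c1cc(OC)c(OC)c(OC)c1` gives 140 nM

These values come from a functional assay on MGC-803 cells (Homo sapiens) for inhibition, read by MTT assay, with a stated time of 48 h (on this read-out higher numbers stand for weaker inhibition and lower numbers for stronger inhibition), and they place compound 3 through two steps. There is a 1.2-fold higher number from compound 2 to compound 3 (0.07 log units; within the scatter) and there is a 2.1-fold higher number from compound 1 to compound 3 (0.33 log units; beyond the scatter) so its number lies close to one neighbour and clear of the other.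

Compound 4 `COc1ccc(CN(C(=O)CCCl)c2cc(OC)c(OC)c(OC)c2)cc1O` carries 2-chloroethyl in place of penta-1,3-dien-1-yl on a carbonyl carbon. Among the compounds with values here, no measured step makes this exact swap, so the guide is the other chains at that carbonyl. Butyl and 1-bromoethyl show a 1.8-fold higher number from compound 1 to compound 2 (0.26 log units; within the scatter) and this leaves them inseparable. The 2-chloroethyl chain most resembles the short halogen-bearing chain of compound 2 with its 120 nM as the nearest reference. The expected step is a 1.4-fold lower number from compound 3 to compound 4 (0.15 log units; within the scatter) and this would be no real change. For compound 4 the estimated value in this assay is 100 nM with an expected range from 45 nM to 240 nM in repeat measurements.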

Compound 4, half-maximal inhibitory concentration: 140 nM
The estimate for compound 4 lay 1.4-fold (0.15 log units) below the measured number; low and high end bracket the measured number.
By their numbers in this assay, from the lowest: compounds 1, 2, 3 and 4 (each within the scatter of the next, the first and the last beyond it).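

In this assay, putting 2-chloroethyl in place of penta-1,3-dien-1-yl on the carbonyl carbon gives no change at the digits printed from compound 3 to compound 4 (within the scatter), and the swap from 1-bromoethyl gives a 1.2-fold higher number from compound 2 to compound 4 (0.07 log units; within the scatter), so this position can lose the double bonds, and the halogen can change from bromine to chlorine, with no readable shift. Only against butyl does the new chain stand apart, with a 2.1-fold higher number from compound 1 to compound 4 (0.33 log units; beyond the scatter), a modest step and the only one of the three beyond the scatter. Nothing measured here explains why these chains read as they do.

The compounds shown leave open whether a chain ending in an amine or a carboxylic acid would keep the number near these values. They also leave open what a chain longer than butyl, or a phenyl ring, would do on this carbonyl carbon.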